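The source may report more compounds than this note shows. Statements on the series, on what has been measured and on what is new or still open speak of the compounds shown alone.

Compound 3 `CC1(C)CCC(CN2CCN(c3ccc(C(=O)NS(=O)(=O)c4ccc(OC5CCOCC5)c([N+](=O)[O-])c4)c(Oc4cnc5[nH]ccc5c4)c3)CC2)=C(c2ccc(C(F)(F)F)cc2)C1` stands at the high end of the three measured numbers in an assay on isolated protein for displacement of a labelled ligand from Apoptosis regulator Bcl-2 (Homo sapiens), with a stated time of 15 min (on this read-out lower numbers stand for stronger inhibition and higher numbers for weaker inhibition), giving 8.4 nM. Compound 1 `CC1(C)CCC(CN2CCN(c3ccc(C(=O)NS(=O)(=O)c4ccc(NCC5CCOC5)c([N+](=O)[O-])c4)c(Oc4cnc5[nH]ccc5c4)c3)CC2)=C(c2ccc(C(F)(F)F)cc2)C1` gives 4.7 nM, and compound 2 `CC1(C)CCC(CN2CCN(c3ccc(C(=O)NS(=O)(=O)c4ccc(NC5CCOC5)c([N+](=O)[O-])c4)c(Oc4cnc5[nH]ccc5c4)c3)CC2)=C(c2ccc(C(F)(F)F)cc2)C1` gives 1.9 nM. The two steps into compound 3 differ in size: a 1.8-fold higher number from compound 1 to compound 3 (0.25 log units; within the scatter), while a 4.4-fold higher number from compound 2 to compound 3 (0.65 log units; beyond the scatter). Compound 4 `CN1CCC(COc2ccc(S(=O)(=O)NC(=O)c3ccc(N4CCN(CC5=C(c6ccc(C(F)(F)F)cc6)CC(C)(C)CC5)CC4)cc3Oc3cnc4[nH]ccc4c3)cc2[N+](=O)[O-])C1` differs from compound 3 by (1-methylpyrrolidin-3-yl)methyl in place of oxan-4-yl on an oxygen on an aromatic ring. Neither measured step bears directly on this change, since both replace an amino-linked group with an oxygen-linked one rather than varying the group on the oxygen. With no guidance beyond that, a shift of no more than the scatter is expected in this assay. The expected step is a 1.2-fold lower number from compound 3 to compound 4 (0.08 log units; within the scatter). Compound 4 is therefore estimated at 7 nM, within 2.5 nM to 20 nM.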

Compound 4, half-maximal inhibitory concentration: 0.75 nM
Compound 4: middle estimate off by 9.3-fold (0.97 log units), on the high side; measured number below the stated range.
By their numbers in this assay, from the lowest: compound 4; then compound 2; then compounds 1 and 3 (each within the scatter of the next).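

In this assay, among these compounds, the group on the oxygen on an aromatic ring proves to matter, with an 11-fold lower number from compound 3 to compound 4 (1.05 log units; beyond the scatter) on a change that keeps the oxygen, which no earlier step varied. The oxygen-linked compound 4 also outdoes both amino-linked compounds, with a 2.5-fold lower number from compound 2 to compound 4 (0.40 log units; beyond the scatter) and a 6.3-fold lower number from compound 1 to compound 4 (0.80 log units; beyond the scatter), so an oxygen link does not by itself give the weaker number seen for compound 3. Nothing available explains the size of these steps.

Open, on these data alone, is whether the ring nitrogen carries the gain: (oxolan-3-yl)methyl on the same oxygen would test that. Also open, as far as these compounds go, is how an open-chain dimethylamine on this oxygen would compare.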